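From benzyloxycarbonyl to tert-butoxycarbonyl: compound 2 to compound 3

The source may hold more compounds than are shown below. What is called first, only, known or untested is meant among the compounds shown, and "the series" means these compounds.

In a functional assay on MDA-MB-231 cells (Homo sapiens) for inhibition, read by MTT assay, with a stated time of 72 h (a higher number here means a weaker inhibitor, a lower number a stronger inhibitor), compound 1 `CC(C)[C@H](NC(=O)c1cc(Cl)ccc1OCCN)C(=O)Nc1ccc([N+](=O)[O-])cc1Cl` gives > 10000 nM as a limit of the assay, not a number. Compound 2 `CC(C)[C@H](NC(=O)c1cc(Cl)ccc1OCCNC(=O)OCc1ccccc1)C(=O)Nc1ccc([N+](=O)[O-])cc1Cl` gives > 10000 nM as a limit too, and so stands without a number of its own. The record so far is the limit of > 10000 nM in this assay, at which 2 of the 2 values shown sit, and no more. Among the measured compounds shown here, the only measured step is a step that the two limits leave unreadable from compound 1 to compound 2 and it offers no size to carry forward.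

Compound 3 `CC(C)[C@H](NC(=O)c1cc(Cl)ccc1OCCCNC(=O)OC(C)(C)C)C(=O)Nc1ccc([N+](=O)[O-])cc1Cl` differs from compound 2 by ((tert-butoxycarbonyl)amino)methyl in place of (benzyloxycarbonyl)amino on a saturated chain carbon, two bonds along the chain from an oxygen on an aromatic ring with ((tert-butoxycarbonyl)amino)methyl in place of (benzyloxycarbonyl)amino on a saturated chain carbon, two bonds along the chain from an oxygen on an aromatic ring. Cut one bond further out, the same difference reads ((benzyloxycarbonyl)amino)methyl to 2-((tert-butoxycarbonyl)amino)ethyl.

For the measured compounds named here, since the step that the two limits leave unreadable from compound 1 to compound 2 has no readable size, no step of known size or direction is expected in this assay for this change. The expected step that the limit leaves unreadable from compound 2 to compound 3 is an estimate with no measured size behind it. For compound 3 the estimated value is 12000 nM with an expected range of 4000 nM to 30000 nM and a report as a limit is the likeliest outcome.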

Compound 3, half-maximal inhibitory concentration: > 10000 nM
Compound 3 ended at the assay's limit; the forecaster's own chance of this, stated with the estimate: 75%; the middle value lies beyond the limit too.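

In this assay compound 3 gives > 10000 nM, a limit and not a number. Compound 1 and compound 2 are also limits, so the steps among these three compounds cannot be read. The compounds shown leave open whether any change to this chain on the shared core gives a measurable value in this assay: the limit of > 10000 nM in this assay, at which 3 of the 3 values shown sit.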